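The compounds below may be only part of what the source reports. "The series", "measured", "known", "first", "only" and "open" are said of these compounds alone.

Among the measured compounds shown here, in an ADME assay on L6 cells (Rattus norvegicus) for cytotoxicity, read by resazurin assay, with a stated time of 72 h (a higher number here means a weaker inhibitor, a lower number a stronger inhibitor), two compounds have numbers so far. Compound 1 `N=C(N)c1cc(I)c(OCc2cccc([N+](=O)[O-])c2)c(I)c1` gives 7720000 nM. Compound 2 `N=C(N)c1ccc(COc2ccc([N+](=O)[O-])cc2)cc1` gives 79200000 nM, the higher of the two numbers, and its gap to compound 1 lies beyond the scatter. These two compounds differ in more than one place, so their gap says nothing about any single group.

Compound 3 `N=C(N)c1ccc(COc2ccc(N)cc2)cc1` is the next compound to be read in this assay. It comes from compound 2 by one change: amino in place of nitro on an aromatic carbon. In words, this is amino in place of nitro on an aromatic carbon, para to a large group.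

For the measured compounds named here, no measured pair isolates a change of this kind, so the expectation is loose. A modest move to a lower number is expected, not far beyond the scatter, since compound 2 at 79200000 nM is the top of the numbers seen so far. The expected change is a 1.6-fold lower number from compound 2 to compound 3 (0.20 log units; within the scatter). The estimated value for compound 3 is 50000000 nM, with an expected range from 15000000 nM to 150000000 nM.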

Compound 3, half-maximal inhibitory concentration: > 271000000 nM
Compound 3: only a limit was reported; the forecaster's own chance of this, stated with the estimate: 15%; middle value at least 5.4-fold (0.73 log units) from the limit.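

Amino in place of nitro on an aromatic carbon, para to a large group, gives an at least 3.4-fold higher number from compound 2 to compound 3 (0.53 log units; beyond the scatter), the first step in the series that isolates a single place. In this assay compound 3 gives > 271000000 nM, which is a limit and not a number. At this position, then, the change moves the reading towards weaker inhibition by more than the scatter, but the true size of the step stays unset, and only its lower bound can be read: the limit of > 271000000 nM in this assay, at which 1 of the 3 values shown sits.

The compounds shown leave open whether the step follows from the arrival of amino or from the loss of nitro, a question that a bare hydrogen, a methoxy group or a nitrile at the same place would help to separate. Among the compounds shown here, also open is whether amino in place of nitro moves the number the same way on the core of compound 1, since compound 1 and compound 2 differ in more than one place and no single step connects them.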